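The source may report more compounds than this note shows. Statements on the series, on what has been measured and on what is new or still open speak of the compounds shown alone.

The three measured compounds share one core, carried in compound 1 `CC(C)(C)c1ccc(CN2C(=O)S/C(=C\c3ccc(N)cc3)C2=O)cc1`, compound 2 `Nc1ccc(/C=C2\SC(=O)N(Cc3cccc(Cl)c3)C2=O)cc1` and compound 3 `Cc1ccc(CN2C(=O)S/C(=C\c3ccc(N)cc3)C2=O)cc1`. In a functional assay on HeLa cells (Homo sapiens) for cytotoxicity, read by cell counting, with a stated time of 4 days (a lower number here means a stronger inhibitor, a higher number a weaker inhibitor), compound 1 gives 53000 nM. In this assay compound 2 gives 24000 nM. For compound 3 the assay reports only a limit, > 250000 nM, so compound 3 stands at the weak end of what is shown, at the limit of > 250000 nM in this assay, at which 1 of the 3 values shown sits. Two measured steps lead to it: an at least 4.7-fold higher number from compound 1 to compound 3 (0.67 log units; beyond the scatter), and an at least 10-fold higher number from compound 2 to compound 3 (1.01 log units; beyond the scatter). Compound 4 `Nc1ccc(/C=C2\SC(=O)N(Cc3ccccc3)C2=O)cc1` has not yet been measured and differs from compound 3 by hydrogen in place of methyl on an aromatic carbon. Neither measured step repeats this change, yet both run toward compound 3 and both weaken, and the step from compound 1 shows that shrinking the group on that aromatic carbon already cost activity. Taking the methyl away goes one step further in the same direction, so no recovery is expected. Compound 4 is therefore estimated at 250000 nM, between 60000 nM and 1000000 nM, meaning a number no higher from compound 3 to compound 4 (the limit leaves the size open), with a real chance that the assay again returns only a limit.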

Compound 4, half-maximal inhibitory concentration: 46000 nM
Compound 4: middle estimate off by 5.4-fold (0.74 log units), on the high side, outside the stated range (below it).
By their numbers in this assay, from the lowest: compounds 2, 4 and 1 (each within the scatter of the next, the first and the last beyond it). At a limit, above all of these: compound 3.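

Taking the methyl off the carbon para to a large group does not weaken the compound further in this assay: the change gives an at least 5.4-fold lower number from compound 3 to compound 4 (0.73 log units; beyond the scatter), so the 4-methylphenyl to phenyl change is a gain of unknown size. The phenyl compound also lies within the scatter of its two other neighbours, with a 1.9-fold higher number from compound 2 to compound 4 (0.28 log units; within the scatter) for hydrogen in place of chloro and a 1.2-fold lower number from compound 1 to compound 4 (0.06 log units; within the scatter) for hydrogen in place of tert-butyl, so a smaller group does not in itself cost activity, and compound 3 alone stands apart from this. Compound 3 has only a limit, not a number: the limit of > 250000 nM in this assay, at which 1 of the 4 values shown sits.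

Going by these compounds, whether a methoxy group or an amine on that aromatic carbon would behave like hydrogen and tert-butyl or like methyl stays open. So does whether an ethyl group there would share the loss seen with methyl.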